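The compounds below may be only part of what the source reports. "The series", "measured", "known", "first", "only" and "open" are said of these compounds alone.

Measured in an ADME assay on microsomes from liver (Homo sapiens) for metabolic stability, with a stated time of 10 min, tested at 0.5 uM; on this read-out higher numbers stand for a more stable compound and lower numbers for a less stable compound:
- Compound 1 `Cc1noc(C)c1[C@@H]1C[C@@](C)(c2ccc(F)cc2F)N=C(N)S1`: 24%
- Compound 2 `CCc1noc(C)c1[C@@H]1C[C@@](C)(c2ccc(F)cc2F)N=C(N)S1`: 21%
- Compound 3 `Cn1nccc1[C@@H]1C[C@@](C)(c2ccc(F)cc2F)N=C(N)S1`: 70%

Compound 3, at 70%, stands highest of the three, and its distance from each of the other two lies beyond the scatter. The next compound, compound 4 `C[C@@]1(c2ccc(F)cc2F)C[C@@H](c2cncnc2)SC(N)=N1`, keeps the shared core and changes one group: pyrimidin-5-yl in place of 1-methyl-1H-pyrazol-5-yl on a saturated ring carbon. The group sits on a saturated ring carbon, next to the ring sulfur.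

Two measured steps changed the group at this same place, a number 46 percentage points higher from compound 1 to compound 3 (beyond the scatter) and a number 49 percentage points higher from compound 2 to compound 3 (beyond the scatter). Both were large, so this place can clearly move the read-out. The third step, a number 3 percentage points lower from compound 1 to compound 2 (within the scatter), altered only a chain on the 1,2-oxazole group and stayed within the scatter. Among the measured compounds shown here, no measured compound carries pyrimidin-5-yl, so the size of the new step cannot be read from the data. For the measured compounds named here, the large steps show only that a swap here may matter, and their direction gives no firm guide for this one. With compound 3 as the closest reference at 70%, no change beyond the scatter is expected in this assay, and the expected move is a number 3 percentage points higher from compound 3 to compound 4 (within the scatter). Compound 4 is expected at 73%. The estimated range for compound 4 runs from 50% to 91%.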

Compound 4, percent of the compound remaining: 90%
Estimate against measurement, compound 4: 17 percentage points below; measured number inside the range.
By their numbers in this assay, from the lowest: compounds 2 and 1 (each within the scatter of the next); then compound 3; then compound 4.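

In this assay, pyrimidin-5-yl and 1-methyl-1H-pyrazol-5-yl have the same counts of heavy atoms, carbon, nitrogen and hydrogen-bond acceptors, yet the exchange still gives a number 20 percentage points higher from compound 3 to compound 4 (beyond the scatter). At this saturated ring carbon, then, a change of a five-membered for a six-membered aromatic ring with those counts untouched is enough to move the read-out, and against the two 1,2-oxazole groups the steps widen to a number 66 percentage points higher from compound 1 to compound 4 (beyond the scatter) and a number 69 percentage points higher from compound 2 to compound 4 (beyond the scatter), which places compound 4 at the top of the four compounds. Nothing available accounts for the difference between these groups.

The compounds shown leave open whether the higher number belongs to the six-membered aromatic ring as such or to the two ring nitrogens of pyrimidin-5-yl, a question that a phenyl or a pyridin-3-yl group at the same ring carbon would address. From the compounds shown here alone, it also remains open whether a methyl group or an amine added to the pyrimidin-5-yl ring would keep the read-out at this level.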